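Extending the chain of compound 3

This account rests on a few compounds, and the source may have more. Where it says the series, first, only, none or still open, it means among the compounds named here.

Compound 1 `COC(=O)c1cc(N2C(=O)C3=C(CCCC3)C2=O)c(F)cc1Cl` gives 110 nM
Compound 2 `CCOC(=O)c1cc(N2C(=O)C3=C(CCCC3)C2=O)c(F)cc1Cl` gives 100 nM
Compound 3 `CCOC(=O)c1cc(N2C(=O)C3=C(CCCC3)C2=O)ccc1Cl` gives 1380 nM

In a functional assay on the whole organism with Scenedesmus acutus as the target (a higher number here means a weaker inhibitor, a lower number a stronger inhibitor), compound 3 has the highest number of the three and is the weakest inhibitor here. Compound 4 `CCCCCOC(=O)c1cc(N2C(=O)C3=C(CCCC3)C2=O)ccc1Cl` differs from it by propyl in place of hydrogen on a saturated chain carbon, two bonds along the chain from an oxygen next to a carbonyl group and this turns ethoxy into pentyloxy. For the measured compounds named here, the one measured change on this chain is smaller and was made with fluoro present: a 1.1-fold lower number from compound 1 to compound 2 (0.04 log units; within the scatter) stays within the scatter. The larger 14-fold higher number from compound 2 to compound 3 (1.14 log units; beyond the scatter) concerns the fluoro and not the chain. No measurement covers a chain this long, so no firm direction can be given, and no change beyond the scatter is expected. The expected step is a 1.1-fold higher number from compound 3 to compound 4 (0.04 log units; within the scatter) in this assay with wide uncertainty. The estimate for compound 4 is 1500 nM (range 500 nM to 4500 nM).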

Compound 4, half-maximal inhibitory concentration: 9330 nM
Compound 4: the middle estimate sits 6.2-fold (0.79 log units) below what was measured, outside the stated range (above it).
By their numbers in this assay, from the lowest: compounds 2 and 1 (each within the scatter of the next); then compound 3; then compound 4.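

In this assay the chain at this position does matter once it grows: turning ethoxy into pentyloxy gives a 6.8-fold higher number from compound 3 to compound 4 (0.83 log units; beyond the scatter) and so a weaker inhibitor. The shorter change on this chain, made with fluoro present, gave only a 1.1-fold lower number from compound 1 to compound 2 (0.04 log units; within the scatter) and stayed within the scatter. Adding propyl at this carbon is therefore not neutral, at least in the absence of fluoro. No measured evidence here bears on why the longer chain weakens inhibition. The compounds shown leave open whether the loss builds gradually through propoxy and butoxy chains or appears suddenly. They also leave open whether pentyloxy costs as much when fluoro is present.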